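The source may hold more compounds than are shown below. What is called first, only, known or untested is meant among the compounds shown, and "the series" means these compounds.

Measured in an ADME assay on NIH3T3 cells (Mus musculus) for cytotoxicity; on this read-out lower numbers stand for higher toxicity in this test and higher numbers for lower toxicity in this test:
- compound 1 `CN1CCN(CC#Cc2cc3c(Nc4ccc(OCc5cccc(F)c5)c(Cl)c4)ncnc3s2)CC1`: 6.7 uM
- compound 2 `CCOC(=O)CN(C)CC#Cc1cc2c(Nc3ccc(OCc4cccc(F)c4)c(Cl)c3)ncnc2s1`: > 50 uM (a limit)

Compound 2 has only > 50 uM, which is a limit of the assay and not a number. It therefore stands at the top of the two values shown, with its true position unknown.

The next compound is compound 3 `CC(C)(C)CC#Cc1cc2c(Nc3ccc(OCc4cccc(F)c4)c(Cl)c3)ncnc2s1`, with tert-butyl in place of ((ethoxycarbonyl)methyl)(methyl)amino on a saturated chain carbon bound to a triple-bonded carbon.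

Going by the values given here, one measured step bears on this change, as it alters the same position: an at least 7.4-fold higher number from compound 1 to compound 2 (0.87 log units; beyond the scatter). From the compounds shown here alone, that step is beyond the scatter, and its full size stays open given (the limit of > 50 uM in this assay, at which 1 of the 2 values shown sits). Neither compound carries tert-butyl, so the step shows that this position can matter in this assay, but it does not fix the direction for the new group.

A moderate move to a lower number is expected, no larger than the measured step, and a further limit reading remains possible. The expected step is an at least 1.6-fold lower number from compound 2 to compound 3 (0.22 log units; that floor lies within the scatter). Compound 3 is estimated at 30 uM, with an expected range of 10 uM to 90 uM.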

Compound 3, half-maximal toxic concentration: > 50 uM
Compound 3: only a limit was reported; the forecaster's own chance of this, stated with the estimate: 45%; middle value at least 1.6-fold (0.22 log units) away from the limit.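

In this assay, tert-butyl in place of 4-methylpiperazin-1-yl on a saturated chain carbon bound to a triple-bonded carbon gives an at least 7.4-fold higher number from compound 1 to compound 3 (0.87 log units; beyond the scatter), so the earlier shift at this position is not confined to ((ethoxycarbonyl)methyl)(methyl)amino and also appears with an all-carbon group that has no hydrogen-bond acceptors. Compound 3 gives > 50 uM in this assay, which is a limit of the assay and not a number. No order between compound 2 and compound 3 can be read, and the size of that step stays unknown, because both sit at the limit: the limit of > 50 uM in this assay, at which 2 of the 3 values shown sit.

Among the compounds shown, only compound 1 gives a reading below the limit, so it remains open whether that reading is particular to 4-methylpiperazin-1-yl or extends to other cyclic amines such as morpholin-4-yl or piperidin-1-yl on the same chain carbon. A simple dimethylamino group, or a carboxylic acid in place of the ethyl ester, would test whether the amine nitrogen alone goes with a lower number in this assay.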